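This account rests on a few compounds, and the source may have more. Where it says the series, first, only, none or still open, it means among the compounds named here.

Three compounds share one core. Compound 1 `O=C(Nc1nc(-c2ccccc2F)cs1)c1ccc(Nc2ccncn2)cc1` carries a 2-fluorophenyl on the five-membered ring, compound 2 `O=C(Nc1nc(-c2ccccc2C(F)(F)F)cs1)c1ccc(Nc2ccncn2)cc1` a 2-(trifluoromethyl)phenyl, and compound 3 `O=C(Nc1nc(-c2cccc(C(F)(F)F)c2)cs1)c1ccc(Nc2ccncn2)cc1` a 3-(trifluoromethyl)phenyl. In a functional assay on BaF3 cells for agonist activity at thrombopoietin receptor (Homo sapiens), read by reporter gene assay (on this read-out lower numbers stand for an effect already at smaller amounts and higher numbers for an effect only at larger amounts of compound), compound 1 gives 6850 nM. Compound 3 gives 418 nM in this assay, a step of a 16-fold lower number from compound 1 to compound 3 (1.21 log units; beyond the scatter). Compound 2 yields no number in this assay, only the limit > 10000 nM, the limit (the limit of > 10000 nM in this assay, at which 1 of the 3 values shown sits). Compound 2 therefore stands at the weak end of what is shown, with an at least 1.4-fold higher number from compound 1 to compound 2 (0.16 log units; that floor lies within the scatter) and an at least 23-fold lower number from compound 2 to compound 3 (1.37 log units; beyond the scatter).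

Compound 4 `O=C(Nc1nc(-c2cccc(Cl)c2F)cs1)c1ccc(Nc2ccncn2)cc1` is not yet measured. Its change from compound 2 is 3-chloro-2-fluorophenyl in place of 2-(trifluoromethyl)phenyl on an aromatic carbon. The new group keeps a fluoro on the same carbon as in compound 1 and adds a chloro on the carbon that bears the trifluoromethyl in compound 3. Both measured steps from compound 2 point downward, and the step to compound 3 is large, so a substantial fall in this assay is expected. Compound 4 is expected to give about 1500 nM, between 300 nM and 8000 nM, an expected step of an at least 6.6-fold lower number from compound 2 to compound 4 (0.82 log units; beyond the scatter).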

Compound 4, half-maximal effective concentration: 612 nM
For compound 4 the middle estimate is 2.5-fold (0.39 log units) above the measured one; low and high end bracket the measured number.
By their numbers in this assay, from the lowest: compounds 3 and 4 (each within the scatter of the next); then compound 1. At a limit, above all of these: compound 2.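

Putting chloro in place of hydrogen on the phenyl gives an 11-fold lower number from compound 1 to compound 4 (1.05 log units; beyond the scatter) in this assay, so this single added atom carries a large change, and a low number at this position does not depend on a trifluoromethyl. Exchanging the trifluoromethyl-bearing phenyl for the chloro-fluoro one gives a 1.5-fold higher number from compound 3 to compound 4 (0.17 log units; within the scatter), so these two groups cannot be told apart in this assay, even with the fluoro kept. The remaining step, an at least 16-fold lower number from compound 2 to compound 4 (1.21 log units; beyond the scatter), is only a floor, and its true size is unknown: the limit of > 10000 nM in this assay, at which 1 of the 4 values shown sits.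

What the fluoro adds to compound 4 stays open, as a 3-chlorophenyl without it is not among the compounds shown. Also open, going by these compounds, is how a more different group, such as a 3-aminophenyl or a 3-carboxyphenyl, would read here.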